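The source may hold more compounds than are shown below. What is called first, only, known or untested is meant among the compounds shown, and "the series" means these compounds.

Compound 2, with the structure `CC[C@H](C)[C@H](N)CN(C(=O)[C@@H]1C[C@H]1c1ccc(C#N)cc1)c1ccc(-c2ccccc2)cc1`, gives in a functional assay for agonist activity at G protein-coupled receptor 88 (Homo sapiens), read by HTRF and cAMP accumulation (on this read-out lower numbers stand for an effect already at smaller amounts and higher numbers for an effect only at larger amounts of compound), no number but only a limit of > 25000 nM. That limit is the one recorded as the limit of > 25000 nM in this assay, at which 1 of the 2 values shown sits, and it says no more than that compound 2 reaches no measurable effect within the tested range. Compound 1, whose structure is `CC(C)CCNCCN(C(=O)[C@@H]1C[C@H]1c1ccccc1)c1ccc(-c2ccccc2)cc1`, stands elsewhere: in this assay compound 1 gives 5.1 nM. Among the measured compounds shown here, no single-point step joins compound 1 and compound 2, so their two values are simply set side by side. Compound 3, the structure `CC[C@H](C)[C@H](N)CN(C(=O)[C@@H]1C[C@H]1c1ncc(C)s1)c1ccc(-c2ccccc2)cc1`, has not yet been measured. It differs from compound 2 in one place: 5-methyl-1,3-thiazol-2-yl in place of 4-cyanophenyl on a saturated ring carbon No measured step of this kind is available among the compounds shown, and compound 2 itself sits at the limit, so any movement in this assay can only be judged from where that limit lies. Compound 3 is expected to show a step of an at least 1.6-fold lower number from compound 2 to compound 3 (0.22 log units; that floor lies within the scatter), towards smaller values but modest. The estimate for compound 3 in this assay is 15000 nM, with a range from 2500 nM to 25000 nM.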

Compound 3, half-maximal effective concentration: 1300 nM
The estimate for compound 3 lay 12-fold (1.06 log units) above the measured number; measured number outside the range, below it.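

In this assay, putting 5-methyl-1,3-thiazol-2-yl in place of 4-cyanophenyl on a saturated ring carbon of the three-membered ring gives an at least 19-fold lower number from compound 2 to compound 3 (1.28 log units; beyond the scatter). Among the compounds shown here, the value of compound 2 is only a limit and not a number, so this step is a floor: the limit of > 25000 nM in this assay, at which 1 of the 3 values shown sits. The exchange thus shows that, with the rest of compound 2 unchanged, the group at this one place can separate a limit from a measurable value, something the earlier compounds could not show, as no single-point step joined them.

On these data alone, what a phenyl, or a 1,3-thiazol-2-yl without the methyl, would give at this ring carbon with the same amine chain remains open, so the step cannot be divided among the loss of the nitrile, the change of ring and the methyl. Also open, as far as these compounds go, is whether the same exchange would move compound 1, which gives 5.1 nM in this assay, in the same direction, or would instead leave its value within the usual scatter.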